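Swapping a pyridylmethyl amide for a methoxypyridyl amide

The source may report more compounds than this note shows. Statements on the series, on what has been measured and on what is new or still open speak of the compounds shown alone.

Measured so far:
compound 1, `O=C(Nc1ccccc1)c1c(O)c2cccnc2n(-c2ccccc2)c1=O`: -15%
compound 2, `O=C(Nc1ccncc1)c1c(O)c2cccnc2n(-c2ccccc2)c1=O`: 24.3%
compound 3, `O=C(NCc1cccnc1)c1c(O)c2cccnc2n(-c2ccccc2)c1=O`: 14.7%

All three share one core and differ only in the group on the amide-type nitrogen, tested in a functional assay on the whole organism for inhibition, with Rattus norvegicus as the target, read by cytopathic effect and paw edema, at a dose of 100 mg/kg by the oral route; on this read-out lower numbers stand for less inhibition and higher numbers for more inhibition at the one dose given (going by the name of the read-out). Compound 3 stands second highest of the three: the step of a number 9.6 percentage points lower from compound 2 to compound 3 (within the scatter) lies within the scatter, while the step of a number 29.7 percentage points higher from compound 1 to compound 3 (beyond the scatter) lies beyond it.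

Compound 4, `COc1ccc(NC(=O)c2c(O)c3cccnc3n(-c3ccccc3)c2=O)cn1`, carries the change (6-methoxypyridin-3-yl in place of (pyridin-3-yl)methyl on an amide-type nitrogen). Among the measured compounds shown here, two measured steps bear on it: a number 39.3 percentage points higher from compound 1 to compound 2 (beyond the scatter), a large rise when a ring nitrogen joins the directly attached aryl, and a number 9.6 percentage points lower from compound 2 to compound 3 (within the scatter), within the scatter. Compound 4 again carries a directly attached pyridine ring, so the step of a number 2.3 percentage points higher from compound 3 to compound 4 (within the scatter) is expected to stay within the scatter. Compound 4 is therefore estimated at 17%, ranging from -8% to 40%.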

Compound 4, a percentage reported as inhibition, in the whole organism at one dose (the size of the read-out at that dose, not a potency): -10.2%
Estimate against measurement, compound 4: 27.2 percentage points above, outside the stated range (below it).
By their numbers in this assay, from the lowest: compounds 1 and 4 (each within the scatter of the next); then compounds 3 and 2 (each within the scatter of the next).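

Having a pyridine ring directly on the amide-type nitrogen does not by itself give a higher number in this assay: 6-methoxypyridin-3-yl gives a number 34.5 percentage points lower from compound 2 to compound 4 (beyond the scatter) and a number 24.9 percentage points lower from compound 3 to compound 4 (beyond the scatter). Its a number 4.8 percentage points higher from compound 1 to compound 4 (within the scatter) means that compound 4 cannot be told apart from the phenyl amide, compound 1. Nothing measured here explains this result.

The compounds shown leave open whether the methoxy group or the place of the ring nitrogen accounts for the difference from compound 2. An unsubstituted pyridin-3-yl, or an amine in place of the methoxy, would help separate these two changes.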